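Sulfonyl to Sulfanyl Swap on Enone Growth Inhibitors

The source may report more compounds than this note shows. Statements on the series, on what has been measured and on what is new or still open speak of the compounds shown alone.

Compound 1 `COc1ccc(/C=C(/SCc2ccc(F)cc2)C(=O)c2ccc(Cl)cc2)c(OC)c1OC`, compound 2 `O=C(/C(=C\c1ccccc1OCc1ccccc1)S(=O)(=O)Cc1ccc(Cl)cc1)c1ccc(Br)cc1` and compound 3 `COc1ccc(/C=C(\C(=O)c2ccc(Cl)cc2)S(=O)(=O)Cc2ccc(Cl)cc2)c(OC)c1OC` share an enone chain carrying a benzyl-linked sulfur group. In a functional assay on DU-145 cells (Homo sapiens) for inhibition, read by trypan blue exclusion, with a stated time of 96 h (a lower number here means a stronger inhibitor of growth, a higher number a weaker inhibitor of growth), compound 1 gives 10000 nM, compound 2 gives 10000 nM and compound 3 gives 10000 nM. Compound 3 and compound 1 differ in one place, ((4-fluorobenzyl)sulfanyl in place of (4-chlorobenzyl)sulfonyl on a double-bonded chain carbon bound to a carbonyl carbon and a double-bonded chain carbon), and the step of no change at the digits printed from compound 3 to compound 1 (within the scatter). Compound 2 stands level with both; the difference between its core and that of compound 3 is not broken down here. Compound 4 `O=C(/C(=C\c1ccccc1OCc1ccccc1)SCc1ccc(F)cc1)c1ccc(Br)cc1` is not yet measured and differs from compound 2 by (4-fluorobenzyl)sulfanyl in place of (4-chlorobenzyl)sulfonyl on a double-bonded chain carbon bound to a carbonyl carbon and a double-bonded chain carbon, the same change. Because compound 3 to compound 1 showed no change at the digits printed from compound 3 to compound 1 (within the scatter), the step from compound 2 to compound 4 is expected to be about no change at the digits printed from compound 2 to compound 4 (within the scatter) in this assay. Compound 4 is therefore estimated at 10000 nM, between 5000 nM and 20000 nM.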

Compound 4, concentration for 50% growth inhibition: 1000 nM
For compound 4 the middle estimate is 10-fold (1.00 log units) above the measured one; measured number outside the range, below it.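

In this assay, the swap to (4-fluorobenzyl)sulfanyl gives a 10-fold lower number from compound 2 to compound 4 (1.00 log units; beyond the scatter), so this change did not carry over with the same size from one core to the other: the same change on two cores in this assay, no change at the digits printed (within the scatter) from compound 3 to compound 1 and a 10-fold lower number (1.00 log units; beyond the scatter) from compound 2 to compound 4, 10-fold (1.00 log units) apart, beyond the scatter of two such steps. This shows that the outcome of the swap depends on the core it is made on, so the result on one core is a poor guide to the result on the other. Among these compounds, it does not show which part of the cores is responsible, or whether the sulfur group or the halogen matters, as both change in the one swap.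

The compounds shown leave open how (4-chlorobenzyl)sulfanyl or (4-fluorobenzyl)sulfonyl would behave on either core, which would separate those two changes. They also leave open how an amine would fare in place of the sulfur group.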